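The compounds below may be only part of what the source reports. "The series", "measured", "known", "first", "only" and "open" are said of these compounds alone.

Compound 1 `Nc1nc(NC2CC2)c2ncn(/C=C3/CC3(CO)CO)c2n1` and compound 2 `Nc1nc2c(ncn2/C=C2/CC2(CO)CO)c(=O)[nH]1` were both examined in an ADME assay on CCRF-HSB-2 cells (Homo sapiens) for cytotoxicity, with a stated time of 7 days; on this read-out higher numbers stand for lower toxicity in this test and lower numbers for higher toxicity in this test. For compound 1 the result is a limit of the test, > 20000 nM. For compound 2 the result is likewise a limit, > 20000 nM. Compound 1 thus sits at the limit of > 20000 nM in this assay, at which 2 of the 2 values shown sit, so its toxicity is not pinned down by a number. Compound 3 `Nc1nc(SC2CCCC2)c2ncn(/C=C3/CC3(CO)CO)c2n1` has not yet been measured; it differs from compound 1 by cyclopentylsulfanyl in place of cyclopropylamino on an aromatic carbon. Among the measured compounds shown here, no measured step between compounds is available, and no change beyond the usual scatter is expected, so the step from compound 1 to compound 3 is estimated at a step that the limit leaves unreadable from compound 1 to compound 3. Compound 3 is therefore expected to give about 25000 nM, with a likely range from 8000 nM to 80000 nM.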

Compound 3, half-maximal cytotoxic concentration: 91000 nM
For compound 3 the middle estimate is 3.6-fold (0.56 log units) below the measured one; the measured number lies above the stated range.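

The step from compound 1 to compound 3 cannot be read, because compound 1 gives only a limit of the test rather than a number: the limit of > 20000 nM in this assay, at which 2 of the 3 values shown sit.

The compounds shown leave open how much cyclopentylsulfanyl in place of cyclopropylamino changes the result in this assay.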